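Hydroxy to Amino on Two Related Cores

The source may hold more compounds than are shown below. What is called first, only, known or untested is meant among the compounds shown, and "the series" means these compounds.

Compound 1 `Oc1cccc(/C=C/c2ccccc2O)c1` and compound 2 `Oc1ccc(/C=C/c2cccc(O)c2)cc1` are built from the same atoms joined differently; the difference between the two cores is not broken down here. In an ADME assay on HEK293 cells (Homo sapiens) for inhibition, read by MTT assay, with a stated time of 2 days (on this read-out lower numbers stand for stronger inhibition and higher numbers for weaker inhibition), compound 1 gives 18 ug/mL, while compound 2 gives 1.1 ug/mL, the lowest number among the three measured compounds. Compound 3 `Nc1cccc(/C=C/c2ccccc2O)c1` differs from compound 1 by amino in place of hydroxy on an aromatic carbon; in this assay compound 3 gives 96 ug/mL, and the change brought a 5.3-fold higher number from compound 1 to compound 3 (0.73 log units; beyond the scatter).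

Compound 4 `Nc1ccc(/C=C/c2cccc(O)c2)cc1` has not yet been measured. It differs from compound 2 by amino in place of hydroxy on an aromatic carbon. This is the same kind of change as that made between compound 1 and compound 3, but the place is not identical: in compound 3 the amino sits meta to a group of 9 heavy atoms, whereas in compound 4 it sits para to a group of 9 heavy atoms, on a different core.

A step of about a 5.5-fold higher number from compound 2 to compound 4 (0.74 log units; beyond the scatter) is expected in this assay, resting on the earlier outcome due to a 5.3-fold higher number from compound 1 to compound 3 (0.73 log units; beyond the scatter). Compound 4 is accordingly estimated at 6 ug/mL, most likely between 2 ug/mL and 20 ug/mL.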

Compound 4, half-maximal inhibitory concentration: 25 ug/mL
Estimate against measurement, compound 4: 4.2-fold (0.62 log units) below; the whole stated range lies below it.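

In this assay amino in place of hydroxy on an aromatic carbon again gave a higher number, with a 23-fold higher number from compound 2 to compound 4 (1.36 log units; beyond the scatter) on the second core, so the direction of the step is the same on both cores of this small series. The size of the step did not carry over from one core to the other, and the gap between the two steps is a real one: the same change on two cores in this assay, a 5.3-fold higher number (0.73 log units; beyond the scatter) from compound 1 to compound 3 and a 23-fold higher number (1.36 log units; beyond the scatter) from compound 2 to compound 4, 4.3-fold (0.63 log units) apart, beyond the scatter of two such steps. The pair does not show why the sizes differ, as the core and the place of the change vary together here, and two steps set no rule for any further core.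

The compounds shown leave open whether the larger step belongs to the core of compound 2 or to the place of the change, para to a group of 9 heavy atoms. Also open, as far as these compounds go, is how a methoxy group or a dimethylamino group in the same place would read on either core.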